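The source may report more compounds than this note shows. Statements on the series, on what has been measured and on what is new or still open speak of the compounds shown alone.

Measured in a functional assay on Jurkat cells (Homo sapiens) for cytotoxicity, with a stated time of 72 h; a lower number here means that less compound is needed, a higher number that more compound is needed for the effect:
- compound 1 `C=C[C@@](C)(/C=C/c1ccc(O)c(/C=C/C#N)c1)CCC=C(C)C`: > 49000 nM (a limit)
- compound 2 `C=C[C@@](C)(/C=C/c1ccc(O)c(/C=C/C(=O)NCc2ccc(C(F)(F)F)cc2)c1)CCC=C(C)C`: > 49000 nM (a limit)

Neither compound has a number yet. Compound 1 stands at a limit, > 49000 nM, and not at a measured concentration. Compound 2 also gives only a limit, > 49000 nM. Among the compounds with values here, the whole series so far therefore sits at one point: the limit of > 49000 nM in this assay, at which 2 of the 2 values shown sit. Within the data shown here, no step between measured compounds is available to set a scale.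

The next compound is compound 3 `C=C[C@@](C)(/C=C/c1ccc(O)c(/C=C/c2ccc(Cl)c(Cl)c2)c1)CCC=C(C)C`, which keeps the core of compound 1 and differs from it by one change: 3,4-dichlorophenyl in place of cyano on a double-bonded chain carbon bound to a double-bonded chain carbon. In short, 3,4-dichlorophenyl takes the place of cyano.

With compound 1 resting on its limit of > 49000 nM, any expectation in this assay has a one-sided starting point. A modest move towards lower concentrations is expected, though a further limit is about as likely as a number. The expected change, in estimated terms, is an at least 1.6-fold lower number from compound 1 to compound 3 (0.21 log units; that floor lies within the scatter). The estimate for compound 3 is 30000 nM, with an expected range of 10000 nM to 60000 nM.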

Compound 3, half-maximal effective concentration: > 49000 nM
Compound 3: no number, only a limit; the forecaster's own chance of this, stated with the estimate: 55%; middle value at least 1.6-fold (0.21 log units) away from the limit.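

Compound 3 gives only a limit in this assay, > 49000 nM, so the step from compound 1 to compound 3 cannot be read, and the series stays at one point: the limit of > 49000 nM in this assay, at which 3 of the 3 values shown sit.

Whether 3,4-dichlorophenyl in place of cyano changes the concentration needed in this assay remains open, since the compounds shown give no number.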